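The compounds below may be only part of what the source reports. "The series", "measured", "known", "first", "only" and "open" are said of these compounds alone.

Measured compounds:
- compound 1 `O=C(Nc1ccc(Oc2ccnc3[nH]ccc23)c(F)c1)c1cc2cccnc2n(-c2ccccc2)c1=O`: 180 nM
- compound 2 `O=C(Nc1ccc(Oc2ccnc3[nH]ccc23)c(F)c1)c1cc2cccnc2n(-c2ccc(Cl)cc2)c1=O`: "not determined" (no result reported)
- compound 3 `COc1ccc(-n2c(=O)c(C(=O)Nc3ccc(Oc4ccnc5[nH]ccc45)c(F)c3)cc3cccnc32)cc1`: "not determined" (no result reported)

In a functional assay on NCI-H460 cells (Homo sapiens) for antiproliferative activity, read by MTT assay, with a stated time of 72 h (a lower number here means a stronger inhibitor, a higher number a weaker inhibitor), compound 1 gives 180 nM. For compound 2 and compound 3 no single number is reported in this assay, so compound 3 stands without a value of its own and cannot be placed against compound 1. The step to compound 4 `O=C(Nc1ccc(Oc2ccnc3[nH]ccc23)c(F)c1)c1cc2cccnc2n(-c2ccc(F)c(Cl)c2)c1=O` is 3-chloro-4-fluorophenyl in place of 4-methoxyphenyl on an aromatic nitrogen. For the measured compounds named here, with no measured step in this assay across this series, the only anchor is compound 1, whose unsubstituted phenyl on the same aromatic nitrogen gives 180 nM; a change of this kind on that ring is expected to move the result by no more than the usual scatter, in no set direction. Compound 4 is therefore expected to give about 160 nM in this assay, within 40 nM to 650 nM.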

Compound 4, half-maximal inhibitory concentration: 1050 nM
Estimate against measurement, compound 4: 6.6-fold (0.82 log units) below; measured number above the stated range.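

In this assay, for the compounds shown here, the group on the aromatic nitrogen proves able to move the result: 3-chloro-4-fluorophenyl in place of phenyl gives a 5.8-fold higher number from compound 1 to compound 4 (0.77 log units; beyond the scatter) and is the first measured step at this position. The steps involving compound 2 and compound 3 cannot be read, so the 4-methoxyphenyl and 4-chlorophenyl groups remain unplaced. No evidence here bears on why the number rises. As far as these compounds go, whether the chlorine or the fluorine alone would give the same rise stays open, as does how a morpholine or a carboxylic acid on this phenyl would read.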